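Cytotoxicity notes: replacing the side chain of compound 1

The source may report more compounds than this note shows. Statements on the series, on what has been measured and on what is new or still open speak of the compounds shown alone.

In an ADME assay on BaF3 cells (Mus musculus) for cytotoxicity, read by CellTiter-Glo and CCK-8 assay, with a stated time of 72 h (on this read-out higher numbers stand for weaker inhibition of growth and lower numbers for stronger inhibition of growth), compound 1 (`C=CS(=O)(=O)NCc1ccc(C(=O)Nc2ccc(C)c(Nc3nccc(-c4cccnc4)n3)c2)cc1`) gives 7710 nM and compound 2 (`Cc1ccc(NC(=O)c2ccc(CNC(=O)c3cccnc3)c(C(F)(F)F)c2)cc1Nc1nccc(-c2cccnc2)n1`) gives 8330 nM so these two numbers lie within the scatter of each other and cannot be ranked. Compound 3 (`CCC(=O)Nc1ccc(C(=O)Nc2ccc(C)c(Nc3nccc(-c4cccnc4)n3)c2)cc1`) has no number yet. Compared with compound 1 it carries propanoylamino in place of ((vinylsulfonyl)amino)methyl on an aromatic carbon of a six-membered aromatic ring of carbon only, para to a large group (propanoylamino in place of ((vinylsulfonyl)amino)methyl on an aromatic carbon). Going by the values given here, the series offers no measured pair that isolates this change, so its size cannot be read directly from the data. Among the compounds with values here, the only anchors are compound 1 at 7710 nM and compound 2 at 8330 nM and the expectation rests on those two numbers alone. No shift beyond the scatter is expected in either direction, and the estimated change is a 1.0-fold higher number from compound 1 to compound 3 (0.02 log units; within the scatter) in this assay with wide uncertainty. For compound 3 the expected value is 8000 nM with an estimated range from 3000 nM to 20000 nM in this assay on this limited evidence.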

Compound 3, concentration for 50% growth inhibition: > 10000 nM
Compound 3: only a limit was reported; the forecaster's own chance of this, stated with the estimate: 15%; middle value at least 1.2-fold (0.09 log units) from the limit.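

Notes on the step from compound 1 to compound 3

In this assay compound 3 gives > 10000 nM, which is a limit of the assay and not a number. Going by these compounds alone, putting propanoylamino in place of ((vinylsulfonyl)amino)methyl gives an at least 1.2-fold higher number from compound 1 to compound 3 (0.11 log units; that floor lies within the scatter), the first single-place step in these notes, and it shows no stronger inhibition of growth from this change on the aromatic carbon, para to a large group, while its floor leaves open whether inhibition weakens at all. For this position the data therefore give only a one-sided bound and no size for the change: the limit of > 10000 nM in this assay, at which 1 of the 3 values shown sits.

The step swaps the whole side chain at once, so the vinyl group, the sulfonyl group and the methyl linker cannot be told apart, and a group such as ((ethylsulfonyl)amino)methyl or (acryloylamino)methyl would be needed to separate them. On these data alone, whether an amine, a carboxylic acid or a longer chain at this place would give a reading inside the range of this assay also stays open.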